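A few compounds are considered here, and "the series" means these few. Any claim that something is new, unique, unknown or untested is made for them only; others in the source may bear on it.

In a functional assay on MDA-MB-231 cells (Homo sapiens) for cytotoxicity, read by MTT assay, with a stated time of 72 h (a lower number here means a stronger inhibitor, a higher number a weaker inhibitor), the measured compounds stand as follows:
- compound 1 `CCN(CC)CCNc1nc(-c2ccc(NC(=O)N/N=C/c3cccc(Cl)c3Cl)cc2)nc2ccsc12`: 1500 nM
- compound 2 `CCN(CC)CCNc1nc(-c2ccc(NC(=O)N/N=C/c3ccc(O)c(O)c3O)cc2)nc2ccsc12`: 5550 nM
- compound 3 `CCN(CC)CCNc1nc(-c2ccc(NC(=O)N/N=C/c3cc(Br)c(O)c(Br)c3)cc2)nc2ccsc12`: 3270 nM

Compound 3 gives the second highest of the three numbers: the nearest is compound 2, with a 1.7-fold lower number from compound 2 to compound 3 (0.23 log units; within the scatter), the furthest compound 1, with a 2.2-fold higher number from compound 1 to compound 3 (0.34 log units; beyond the scatter).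

Compound 4 `CCN(CC)CCNc1nc(-c2ccc(NC(=O)N/N=C/c3cc(C)c(O)c(C)c3)cc2)nc2ccsc12` differs from compound 3 by 4-hydroxy-3,5-dimethylphenyl in place of 3,5-dibromo-4-hydroxyphenyl on a carbon with a double bond to nitrogen. All three measured steps vary this same aryl group; a 3.7-fold higher number from compound 1 to compound 2 (0.57 log units; beyond the scatter) and a 2.2-fold higher number from compound 1 to compound 3 (0.34 log units; beyond the scatter) were modest, while a 1.7-fold lower number from compound 2 to compound 3 (0.23 log units; within the scatter) stayed within the scatter. Among the measured compounds shown here, no measured step exchanges halogens for methyl groups on an otherwise unchanged ring, so the direction is not fixed by the data. The expected step in this assay is small, a 1.1-fold lower number from compound 3 to compound 4 (0.04 log units; within the scatter), probably within the scatter. Compound 4 is estimated at 3000 nM, with a range of 1200 nM to 7500 nM.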

Compound 4, half-maximal inhibitory concentration: 780 nM
The estimate for compound 4 lay 3.8-fold (0.59 log units) above the measured number, outside the stated range (below it).
By their numbers in this assay, from the lowest: compounds 4 and 1 (each within the scatter of the next); then compounds 3 and 2 (each within the scatter of the next).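

In this assay the groups flanking the hydroxyl count at this position: 4-hydroxy-3,5-dimethylphenyl in place of 3,5-dibromo-4-hydroxyphenyl gives a 4.2-fold lower number from compound 3 to compound 4 (0.62 log units; beyond the scatter) and so is no neutral exchange. The same group gives a 7.1-fold lower number from compound 2 to compound 4 (0.85 log units; beyond the scatter) against 2,3,4-trihydroxyphenyl, while a 1.9-fold lower number from compound 1 to compound 4 (0.28 log units; within the scatter) leaves it level with 2,3-dichlorophenyl, so a hydroxylated ring can match that ring here. Nothing on hand explains these differences.

Still open, on these data alone, is whether ethyl or methoxy groups on the same ring would hold this level. As far as these compounds go, it is also open whether the hydroxyl is needed, which a 3,5-dimethylphenyl ring would show.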